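The source may report more compounds than this note shows. Statements on the series, on what has been measured and on what is new or still open speak of the compounds shown alone.

Measured compounds:

Compound 1 `C=C[C@@](C)(/C=C/c1ccc(O)cc1)CC/C=C/C(=O)OCC`: in a functional assay on HepG2 cells (Homo sapiens) for cytotoxicity, with a stated time of 72 h (a higher number here means that more compound is needed for the effect, a lower number that less compound is needed), compound 1 gives > 52000 nM, a limit of the assay.
Compound 2 `C=C[C@@](C)(/C=C/c1ccc(O)cc1)CC/C=C/C#N`: in this assay compound 2 gives > 52000 nM, again a limit.
Compound 3 `C=C[C@@](C)(/C=C/c1ccc(O)c(/C=C/C#N)c1)CCC=C(C)C`: in this assay compound 3 gives > 52000 nM, also a limit.

The step from compound 2 to compound 1 is the change (ethoxycarbonyl in place of cyano on a double-bonded chain carbon bound to a double-bonded chain carbon). Its size is a step that the two limits leave unreadable from compound 2 to compound 1. Both values sit at the limit of > 52000 nM in this assay, at which 3 of the 3 values shown sit, so the step cannot be read.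

Compound 4 `C=C[C@@](C)(/C=C/c1ccc(O)c(/C=C/C(=O)OCC)c1)CCC=C(C)C` is not yet measured. It is made from compound 3 by ethoxycarbonyl in place of cyano on a double-bonded chain carbon bound to a double-bonded chain carbon, the same change as from compound 2 to compound 1, at the same place. How the core of compound 3 differs from that of compound 2 is not broken down here.

For compound 4 in this assay the expectation rests on the step from compound 2 to compound 1, where compound 1 gives > 52000 nM, a limit, and on compound 3, which gives > 52000 nM, a limit. The expected step from compound 3 to compound 4 is a step that the limit leaves unreadable from compound 3 to compound 4, that is, no readable change. The estimate for compound 4 in this assay is 80000 nM, with a range from 40000 nM to 200000 nM, and most likely the assay again reports only a limit.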

Compound 4, half-maximal effective concentration: > 52000 nM
Compound 4 ended at the assay's limit; the forecaster's own chance of this, stated with the estimate: 85%; the middle value does not contradict the limit.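

No size can be read for the change from cyano to ethoxycarbonyl between compound 3 and compound 4 in this assay and the same holds between compound 2 and compound 1, because all four compounds sit at one assay limit: the limit of > 52000 nM in this assay, at which 4 of the 4 values shown sit.

The compounds shown leave open whether this change alters cytotoxicity at all, and which structure in the series would give a measurable value.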